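Swapping Pyrrolidine for Imidazole on a Second Core

The source may report more compounds than this note shows. Statements on the series, on what has been measured and on what is new or still open speak of the compounds shown alone.

Compound 1 `CCOC(=O)N(C)CC#CCN1CCCC1` and compound 2 `CCOC(=O)N(C)CC#CCn1ccnc1` differ in one group only: 1H-imidazol-1-yl in place of pyrrolidin-1-yl on a saturated chain carbon bound to a triple-bonded carbon. In a functional assay on the whole organism for antagonist activity, with Mus musculus as the target (a lower number here means that less compound is needed, a higher number that more compound is needed for the effect), compound 1 reaches only a limit of the assay, > 100 mg/kg, not a number. In this assay compound 2 gives 97 mg/kg. The step of an at least 1.0-fold lower number from compound 1 to compound 2 (0.01 log units; that floor lies within the scatter) is bounded by the limit of > 100 mg/kg in this assay, at which 1 of the 3 values shown sits. Compound 3 `CC(C#CCN1CCCC1)N1CCN(C)C1=O` rests on another core; the difference between the two cores is not broken down here. In this assay compound 3 gives 4.5 mg/kg. Compound 4 `CC(C#CCn1ccnc1)N1CCN(C)C1=O` is not yet measured and carries the same kind of change, (1H-imidazol-1-yl in place of pyrrolidin-1-yl on a saturated chain carbon bound to a triple-bonded carbon). The earlier change, an at least 1.0-fold lower number from compound 1 to compound 2 (0.01 log units; that floor lies within the scatter), lay within the scatter. On that basis compound 4 is expected to give about 6 mg/kg, likely between 2 mg/kg and 25 mg/kg, an expected step of a 1.3-fold higher number from compound 3 to compound 4 (0.12 log units; within the scatter).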

Compound 4, dose for half-maximal effect: 21 mg/kg
The estimate for compound 4 lay 3.5-fold (0.54 log units) below the measured number; measured number inside the range.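

In this assay, putting 1H-imidazol-1-yl in place of pyrrolidin-1-yl on the newer core gives a 4.7-fold higher number from compound 3 to compound 4 (0.67 log units; beyond the scatter), so more compound is needed for the effect after the swap. The change does not carry over from one core to the other with the same size: the same change on two cores in this assay, an at least 1.0-fold lower number (0.01 log units; that floor lies within the scatter) from compound 1 to compound 2 and a 4.7-fold higher number (0.67 log units; beyond the scatter) from compound 3 to compound 4, at least 4.8-fold (0.68 log units) apart, beyond the scatter of two such steps. Two cores cannot establish a rule for the whole series, and the step on the core of compound 1 rests on a limit rather than a number: the limit of > 100 mg/kg in this assay, at which 1 of the 4 values shown sits.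

The compounds shown leave open how a piperidin-1-yl or a dimethylamino group would behave on a saturated chain carbon bound to a triple-bonded carbon on either core. They also leave open how large the imidazole swap would be on a third core.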